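This account rests on a few compounds, and the source may have more. Where it says the series, first, only, none or still open, it means among the compounds named here.

Measured compounds in an assay on Jurkat cells for displacement of a labelled ligand from C-X-C chemokine receptor type 4 (Homo sapiens), tested at 10 uM; on this read-out lower numbers stand for less inhibition and higher numbers for more inhibition at the one concentration tested (going by the name of the read-out):
compound 1 `C[C@@H](NC(=O)[C@H](CCCNC(=N)N)NC(=O)c1ccc(CN(Cc2ccc(F)cc2)Cc2cccnc2)cc1)c1cccc2ccccc12` — 6%
compound 2 `C[C@H](NC(=O)[C@H](CCCNC(=N)N)NC(=O)c1ccc(CN(Cc2ccc(F)cc2)Cc2ccccn2)cc1)c1cccc2ccccc12` — 30%
compound 3 `C[C@H](NC(=O)[C@H](CCCNC(=N)N)NC(=O)c1ccc(CN(Cc2ccc(F)cc2)Cc2cccnc2)cc1)c1cccc2ccccc12` — 27%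

Compound 3 stands second highest of the three numbers. Its nearest neighbour is compound 2, whose value lies within the scatter of it: a number 3 percentage points lower from compound 2 to compound 3 (within the scatter). Compound 1 lies furthest away, with a number 21 percentage points higher from compound 1 to compound 3 (beyond the scatter); that step involves only a stereocentre, as shown by the fact that one of compounds 1 and 3 is drawn with a defined configuration and the other without, at the place where they differ.

Compound 4 `C[C@H](NC(=O)[C@H](CCCNC(=N)N)NC(=O)c1ccc(CN(Cc2cccnc2)C(=O)c2ccc(F)cc2)cc1)c1cccc2ccccc12` differs from compound 3 in one place: (4-fluorophenyl)carbonyl in place of 4-fluorobenzyl on an amine nitrogen. For the measured compounds named here, no measured step changes a group of this kind. Going by the values given here, the only step at the same amine nitrogen is the pyridinyl swap between compound 2 and compound 3, which stayed within the scatter, but it exchanged two closely related groups, whereas here a carbonyl enters in place of a saturated chain carbon. The precedent is therefore thin, and the expected step of a number 7 percentage points lower from compound 3 to compound 4 (within the scatter) is set near zero with wide uncertainty. Compound 4 is estimated at 20%, with a range from 3% to 45%.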

Compound 4, a percentage reported as inhibition, at one concentration (the size of the read-out at that concentration, not a potency): 14%
Compound 4: middle estimate off by 6 percentage points, on the high side; measured number inside the range.
By their numbers in this assay, from the lowest: compounds 1 and 4 (each within the scatter of the next); then compounds 3 and 2 (each within the scatter of the next).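

For the compounds shown here, replacing 4-fluorobenzyl with (4-fluorophenyl)carbonyl on the amine nitrogen gives a number 13 percentage points lower from compound 3 to compound 4 (beyond the scatter) in this assay, so this site responds to a change that the earlier compounds did not probe. The pyridinyl swap, a number 3 percentage points lower from compound 2 to compound 3 (within the scatter), had suggested little sensitivity around this nitrogen, but it exchanged two closely related groups, whereas this step puts a carbonyl in place of a saturated chain carbon and adds one hydrogen-bond acceptor. Nothing at hand explains the drop or shows which part of the change goes with it.

On these data alone, it remains open how a sulfonyl linking the 4-fluorophenyl group, or a simple acetyl or methyl group on this nitrogen, would read. Also open, as far as these compounds go, is whether the same step would appear with the pyridin-2-yl group of compound 2 or the opposite stereocentre of compound 1.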